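The compounds below may be only part of what the source reports. "The series", "measured", "known", "first", "only" and "open" are said of these compounds alone.

Measured in a physicochemical assay for lipophilicity, using the shake flask method; on this read-out lower numbers stand for lower lipophilicity and higher numbers for higher lipophilicity:
- compound 1 `CC(C)Oc1cc(Oc2ccc(S(C)(=O)=O)cc2)cc(-c2ccnc(=O)[nH]2)c1`: "not determined" (no result reported)
- compound 2 `CCC(CC)Oc1cc(Oc2cnc(C(=O)N(C)C)nc2)cc(-c2nccc(=O)[nH]2)c1`: 1.91

This series offers little to work from so far. Going by the values given here, for compound 1 no result was reported, so compound 2, at 1.91, holds the only number available in this assay. That value cannot be placed as high or low within the series, since nothing stands beside it.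

The next compound to be measured is compound 3 `C[C@@H](CO)Oc1cc(Oc2cnc(C(=O)N(C)C)nc2)cc(-c2nccc(=O)[nH]2)c1`, which keeps the core and the rest of the substitution of compound 2 and changes one group: 1-(hydroxymethyl)ethyl in place of pentan-3-yl on an oxygen on an aromatic ring. In words, 1-(hydroxymethyl)ethyl stands in place of pentan-3-yl on an oxygen on an aromatic ring.

Among the compounds with values here, no step between measured compounds exists to size this change, so the expectation rests on the structural change alone. A clear move towards lower numbers in this assay is expected, well beyond the usual scatter. The expected change is a number 1.16 log units lower from compound 2 to compound 3 (beyond the scatter). For compound 3 the estimated value is 0.75, with an expected range from 0.3 to 1.2.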

Compound 3, distribution coefficient: -0.02
Compound 3: middle estimate off by 0.77 log units, on the high side; the measured number lies below the stated range.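

At this place, on an oxygen on an aromatic ring, the read-out of this assay now has its first measured step: putting 1-(hydroxymethyl)ethyl in place of pentan-3-yl gives a number 1.93 log units lower from compound 2 to compound 3 (beyond the scatter), so the group on this oxygen has a strong bearing on the number while the rest of the structure stays the same. The exchange alters several things at once, since the entering group has 4 heavy atoms rather than 5, includes 1 oxygen, brings 1 hydrogen-bond donor and 1 hydrogen-bond acceptor where the leaving group has neither, and adds 1 defined stereocentre. No measurement shown here explains the size of this step or assigns it to any one of these differences.

The compounds shown leave open how much of the step belongs to the hydroxyl and how much to the change of carbon skeleton, a question that a propan-2-yl or methoxypropan-2-yl group on the same oxygen could help separate. They also leave open whether the opposite stereocentre, or an amine or a carboxylic acid in place of the hydroxyl, would give a similar number.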